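Fixing both ring stereocentres in the glycine transporter series

A few compounds are considered here, and "the series" means these few. Any claim that something is new, unique, unknown or untested is made for them only; others in the source may bear on it.

Compound 1 `COc1ccc(Sc2ccccc2N2CC(C)N(CC(=O)O)CC2C)cc1` gives 580 nM in an assay for inhibition of sodium- and chloride-dependent glycine transporter 1 (Homo sapiens) (a higher number here means a weaker inhibitor, a lower number a stronger inhibitor), the higher of the two numbers in hand; compound 2 `COc1ccc(Sc2ccc(Cl)cc2N2CCN(CC(=O)O)C(C)C2)cc1` gives 290 nM in this assay, and the gap between the two lies within the scatter. Compound 3 `COc1ccc(Sc2ccccc2N2C[C@@H](C)N(CC(=O)O)C[C@@H]2C)cc1` has not yet been measured. It carries the same atoms and bonds as compound 1 and differs only in drawn configuration: the two compounds have the same atoms and bonds; at least one stereo element is drawn with a configuration in one of them and without one in the other: 2 of 2 stereo elements differ; a stereocentre at a saturated ring carbon is drawn without a configuration in compound 1 and R in compound 3; a stereocentre at a saturated ring carbon is drawn without a configuration in compound 1 and S in compound 3. Among the measured compounds shown here, no measured pair shows what defining these configurations does here, so the expectation is a small step, if any, with the downward direction somewhat more likely than the upward one. Compound 3 is expected at 400 nM, with a range from 150 nM to 1200 nM. The estimated step is a 1.5-fold lower number from compound 1 to compound 3 (0.16 log units; within the scatter).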

Compound 3, half-maximal inhibitory concentration: 160 nM
Compound 3: middle estimate off by 2.5-fold (0.40 log units), on the high side, and the stated range covers the measured number.
By their numbers in this assay, from the lowest: compounds 3, 2 and 1 (each within the scatter of the next, the first and the last beyond it).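

Drawing both ring stereocentres, one R and one S, gives a 3.6-fold lower number from compound 1 to compound 3 (0.56 log units; beyond the scatter) in this assay and is the only listed step between compounds differing in one place. The configuration of these two ring carbons therefore has a measurable bearing on the number in this series, with atoms and bonds unchanged: the fact that one of compounds 1 and 3 is drawn with a defined configuration and the other without, at the place where they differ

Going by these compounds, the other drawn configurations at these two ring carbons remain open. Also open, on these data alone, is whether a tetrazole in place of the carboxylic acid would hold the number with both stereocentres defined.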